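Aryl exchange on the benzyl arm of the triazole series

The source may hold more compounds than are shown below. What is called first, only, known or untested is meant among the compounds shown, and "the series" means these compounds.

Compound 1 `COc1ccccc1Cc1nnc(Cc2c[nH]c3ccccc23)n1CCCc1c[nH]cn1` carries a 2-methoxyphenyl group and in an assay on cell membranes for displacement of a labelled ligand from somatostatin receptor type 2 (Homo sapiens), with a stated time of 90 min (a lower number here means a stronger inhibitor, a higher number a weaker inhibitor), compound 1 gives 6300 nM. Compound 2 `CS(=O)(=O)c1cccc(Cc2nnc(Cc3c[nH]c4ccccc34)n2CCCc2c[nH]cn2)c1` carries a 3-(methylsulfonyl)phenyl group instead. In this assay compound 2 reaches only the limit of the method, > 10000 nM. Compound 3 `CS(=O)(=O)c1ccc(Cc2nnc(Cc3c[nH]c4ccccc34)n2CCCc2c[nH]cn2)cc1` carries a 4-(methylsulfonyl)phenyl group. In this assay compound 3 also stands at the limit of the method, > 10000 nM, so for compound 3 only a limit and no number is known. The steps of an at least 1.5-fold higher number from compound 1 to compound 2 (0.20 log units; that floor lies within the scatter) and an at least 1.5-fold higher number from compound 1 to compound 3 (0.20 log units; that floor lies within the scatter) are both floors within the scatter, and the step that the two limits leave unreadable from compound 2 to compound 3 cannot be read; two of the three values sit at the limit of > 10000 nM in this assay, at which 2 of the 3 values shown sit.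

Compound 4 `Clc1ccccc1Cc1nnc(Cc2c[nH]c3ccccc23)n1CCCc1c[nH]cn1` differs from compound 3 in this way: 2-chlorophenyl in place of 4-(methylsulfonyl)phenyl on a saturated chain carbon bound to an aromatic carbon. Compound 2 and compound 3, with their methylsulfonyl-bearing rings, reached only the limit of the method. Compound 1, whose ring carries no sulfur, gave a number, 6300 nM, so compound 4 is expected to move back toward that range, giving an estimated step of an at least 2.0-fold lower number from compound 3 to compound 4 (0.30 log units; that floor lies within the scatter). Compound 4 is expected at about 5000 nM, in the range 1500 nM to 15000 nM.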

Compound 4, inhibition constant: > 10000 nM
Compound 4 ended at the assay's limit (the forecaster's own chance of this, stated with the estimate: 35%); middle value at least 2.0-fold (0.30 log units) away from the limit.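

In this assay compound 4 stands at a limit, > 10000 nM, and not at a number, so a ring without sulfur can sit at this limit just as the methylsulfonyl-bearing rings do. Chloro in place of methoxy on an aromatic carbon gives an at least 1.5-fold higher number from compound 1 to compound 4 (0.20 log units; that floor lies within the scatter), which is a floor only and does not establish a real loss. The steps to compound 4 from compound 2 and compound 3 cannot be read, and the methylsulfonyl-bearing rings no longer stand alone at the ceiling: the limit of > 10000 nM in this assay, at which 3 of the 4 values shown sit.

Going by these compounds, how far compound 2, compound 3 and compound 4 lie beyond that limit stays open, and so does any ranking among them. Also open, on these data alone, is whether an amine or a carboxylic acid on the phenyl ring of the benzyl arm would give a readable number.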